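The source may report more compounds than this note shows. Statements on the series, on what has been measured and on what is new or still open speak of the compounds shown alone.

Working notes on the sulfonamide series in a functional assay on cells for antagonist activity at C-C chemokine receptor type 4 (Homo sapiens), read by GTPgammaS binding; a higher number here means a weaker inhibitor, a lower number a stronger inhibitor.

Three compounds carry the dichlorophenyl sulfonamide on different fused cores. Compound 1 `Cn1ncc2c(NS(=O)(=O)c3cccc(Cl)c3Cl)cccc21` gives 3160 nM in this assay, and compound 2 `Cn1ncc2c(NS(=O)(=O)c3cccc(Cl)c3Cl)ccnc21` gives 12600 nM. Compound 3 `COc1nn(C(C)C)c2ncnc(NS(=O)(=O)c3cccc(Cl)c3Cl)c12`, with a methoxy group and an isopropyl on the five-membered ring of its core, gives 251 nM and so stands lowest of the three; its gap to compound 1 and its larger gap to compound 2 both lie beyond the scatter. Going by the values given here, no pair among the measured compounds differs in a single place, so no single step has been characterised, and the contribution of any one group to the value of compound 3 is unknown.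

The next compound, compound 4 `COc1nn(CC(=O)O)c2ncnc(NS(=O)(=O)c3cccc(Cl)c3Cl)c12`, keeps the core of compound 3 and changes only the substituent on the aromatic nitrogen: carboxymethyl in place of isopropyl on an aromatic nitrogen. Nothing measured here addresses a carboxymethyl group at this position, so the expectation rests on the value of compound 3 alone. The expected step in this assay, from compound 3 to compound 4, is a 3.2-fold higher number from compound 3 to compound 4 (0.50 log units; beyond the scatter), a modest rise. Compound 4 is estimated at 800 nM, with a range from 200 nM to 3200 nM.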

Compound 4, half-maximal inhibitory concentration: 200 nM
Compound 4: middle estimate off by 4.0-fold (0.60 log units), on the high side; measured number inside the range.
By their numbers in this assay, from the lowest: compounds 4 and 3 (each within the scatter of the next); then compound 1; then compound 2.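

In this assay, going by these compounds alone, the step at this aromatic nitrogen, carboxymethyl in place of isopropyl, is a 1.3-fold lower number from compound 3 to compound 4 (0.10 log units; within the scatter), and it is the first single change characterised. The two substituents therefore cannot be told apart by this read-out, even though the entering carboxymethyl brings oxygen atoms, a hydrogen-bond donor and a hydrogen-bond acceptor that the leaving isopropyl lacks. No supporting data bear on why these two different groups give numbers within the scatter of each other.

As far as these compounds go, one pair cannot show how far this tolerance extends, so it remains open whether a methyl ester or a primary amide in place of the carboxylic acid, a longer chain carrying the acid, or an amine on the same nitrogen would also stay within the scatter of compound 3. From the compounds shown here alone, the contribution of the methoxy group also remains open, as does the question of whether a hydrogen or an ethoxy group in its place would shift the number on a core carrying either carboxymethyl or isopropyl.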